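Swapping Chloro for Methoxy at One Aromatic Position

The source may report more compounds than this note shows. Statements on the series, on what has been measured and on what is new or still open speak of the compounds shown alone.

Compound 1 `CS(=O)(=O)c1ccc(Nc2nccc(Nc3nc4ccc(F)cc4s3)n2)cc1` gives 2080 nM in a functional assay on MDA-MB-231 cells (Homo sapiens) for antiproliferative activity, read by MTT assay, with a stated time of 48 h; on this read-out higher numbers stand for weaker inhibition and lower numbers for stronger inhibition.
Compound 2 `CS(=O)(=O)c1ccc(Nc2nccc(Nc3nc4ccc(Cl)cc4s3)n2)cc1` reaches only the assay's limit, > 50000 nM, in this assay.

Both share the same core and differ only at one aromatic carbon. The step of an at least 24-fold higher number from compound 1 to compound 2 (1.38 log units; beyond the scatter) was a large move toward weaker inhibition, and it ends at the limit described by the limit of > 50000 nM in this assay, at which 1 of the 2 values shown sits, so where compound 2 truly stands is known only as that limit. Compound 3 `COc1ccc2nc(Nc3ccnc(Nc4ccc(S(C)(=O)=O)cc4)n3)sc2c1` carries the change (methoxy in place of chloro on an aromatic carbon). For the measured compounds named here, no measured step covers a chloro-to-methoxy exchange; the single measured step, fluoro to chloro, is the only guide, and it shows that this position can shift this assay strongly. Compound 3 is therefore expected to give about 15000 nM, between 2000 nM and 60000 nM. That expectation corresponds to an at least 3.3-fold lower number from compound 2 to compound 3 (0.52 log units; beyond the scatter), with a real chance that only a limit is again reported.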

Compound 3, half-maximal inhibitory concentration: 32700 nM
The estimate for compound 3 lay 2.2-fold (0.34 log units) below the measured number, within the range that was stated.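

In this assay, a second replacement for fluoro also costs a great deal: a 16-fold higher number from compound 1 to compound 3 (1.20 log units; beyond the scatter), so the large loss at this aromatic carbon is not confined to chloro. The exchange of chloro for methoxy itself gives an at least 1.5-fold lower number from compound 2 to compound 3 (0.18 log units; that floor lies within the scatter), so these data do not establish that methoxy does better than chloro here. Compound 3 gives a real number on this read-out, but the distance from compound 2 stays unknown, since compound 2 has only a limit of the assay: the limit of > 50000 nM in this assay, at which 1 of the 3 values shown sits.

The compounds shown leave open whether the lower number of compound 1 belongs to fluoro alone, or whether an amine, a hydroxyl or a methyl on this aromatic carbon would give a similar number. They also leave open what plain hydrogen at this position would give.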